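Chain-end variation on a shared isoflavone-type core

A few compounds are considered here, and "the series" means these few. Any claim that something is new, unique, unknown or untested is made for them only; others in the source may bear on it.

Measured compounds:
Compound 1 `CC(Oc1ccc2c(=O)c(-c3ccc(O)cc3)coc2c1)C(=O)O` — 2500 nM
Compound 2 `O=c1c(-c2ccc(O)cc2)coc2cc(OCCCCCCCCCCCCO)ccc12` — 1700 nM

Two compounds share the core and differ only in the chain carried on the aromatic oxygen. In an assay (Cricetulus griseus) for inhibition of aldehyde dehydrogenase, mitochondrial (Homo sapiens) (a lower number here means a stronger inhibitor, a higher number a weaker inhibitor), compound 1 gives 2500 nM and compound 2 gives 1700 nM. Compound 2 stands beside compound 1: the gap between the two values is within the usual scatter of repeated measurements, so the data do not separate them.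

Compound 3 `O=C(O)CCCCCCOc1ccc2c(=O)c(-c3ccc(O)cc3)coc2c1` has not yet been measured in this assay. It differs from compound 2 in one place: carboxy in place of 6-hydroxyhexyl on a saturated chain carbon, six bonds along the chain from an oxygen on an aromatic ring. That is, a carboxy group in place of 6-hydroxyhexyl on a saturated chain carbon, six bonds along the chain from an oxygen on an aromatic ring. Compound 1 already carries a carboxy group on its chain, and compound 2 a hydroxyl at the chain end; their values in this assay sit within the scatter of one another, so nothing in hand points in either direction.

Compound 3 is therefore expected to give about 2000 nM in this assay, with a range from 800 nM to 5000 nM. The expected step of a 1.2-fold higher number from compound 2 to compound 3 (0.07 log units; within the scatter) is estimated to be none beyond the scatter.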

Compound 3, half-maximal inhibitory concentration: 50 nM
For compound 3 the middle estimate is 40-fold (1.60 log units) above the measured one, outside the stated range (below it).
By their numbers in this assay, from the lowest: compound 3; then compounds 2 and 1 (each within the scatter of the next).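

In this assay the end of the chain on the aromatic oxygen proves decisive: a carboxy group in place of 6-hydroxyhexyl, on a saturated chain carbon six bonds along the chain from an oxygen on an aromatic ring, gives a 34-fold lower number from compound 2 to compound 3 (1.53 log units; beyond the scatter) and is a large step, whereas the two earlier compounds could not be told apart. A carboxy group alone does not set the number, since compound 1 also carries one; 6-carboxyhexyl in place of 1-carboxyethyl on the same aromatic oxygen gives a 50-fold lower number from compound 1 to compound 3 (1.70 log units; beyond the scatter) and is again large. Among these compounds, the low number therefore goes with the 6-carboxyhexyl chain, and compound 1 shows that a carboxy group on a different chain does not bring it. For the compounds shown here, nothing available explains why either change moves the number so far. The compounds shown leave open how the number follows chain length between 1-carboxyethyl and 6-carboxyhexyl, and whether a longer chain ending in a carboxylic acid would keep it. They also leave open whether a primary amide, a tetrazole or an amine at the chain end could stand in for the carboxy group.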